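The source may report more compounds than this note shows. Statements on the series, on what has been measured and on what is new or still open speak of the compounds shown alone.

Of the compounds shown here, three have numbers so far in a functional assay on FaDu cells (Homo sapiens) for cytotoxicity, read by MTT assay, with a stated time of 72 h; a lower number here means that less compound is tolerated, a higher number that more compound is tolerated. Compound 1 (`COCCc1cc(C(=O)C(=O)Nc2ccc(OC(F)(F)F)cc2)c2ccccn12`) gives 758 nM and compound 2 (`COCCn1cc(C(=O)C(=O)Nc2ccc(OC(C)(C)C)nc2)c2ccccc21`) gives 858 nM, so these two lie within the usual scatter of each other. Compound 3 (`CCc1cc(C(=O)C(=O)Nc2ccc(OC)nc2)c2ccccn12`) gives 110 nM, a number lower than that of compound 2 by more than the scatter. Compound 2 thus stands with compound 1 at the upper end of this small set.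

Compound 4 (`CCOC(=O)COc1ccc(NC(=O)C(=O)c2cn(CCOC)c3ccccc23)cn1`) carries (ethoxycarbonyl)methyl in place of tert-butyl on an oxygen on an aromatic ring. Going by the values given here, no measured pair shows this exchange, so the data give no direct guide to its size. The measured numbers run only from compound 3 at 110 nM to compound 2 at 858 nM, which argues for a modest expectation: a small move towards a lower number, perhaps none beyond the scatter in this assay. The expected step is a 1.9-fold lower number from compound 2 to compound 4 (0.28 log units; within the scatter). For compound 4 the estimate is 450 nM, with an expected range of 130 nM to 1300 nM.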

Compound 4, concentration lethal to 50% of the cells: > 10000 nM
Compound 4 was reported as a limit (the forecaster's own chance of this, stated with the estimate: 2%); middle value at least 22-fold (1.34 log units) from the limit.
By their numbers in this assay, from the lowest: compound 3; then compounds 1 and 2 (each within the scatter of the next). At a limit, above all of these: compound 4.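

Going by these compounds alone, exchanging tert-butyl for (ethoxycarbonyl)methyl on an oxygen on an aromatic ring gives an at least 11-fold higher number from compound 2 to compound 4 (1.06 log units; beyond the scatter) in this assay, so what this oxygen carries can matter far more than the earlier compounds could show. For compound 4, > 10000 nM is a limit and not a number. Of the compounds shown, only this one stands there: the limit of > 10000 nM in this assay, at which 1 of the 4 values shown sits.

On these data alone, it remains open which part of (ethoxycarbonyl)methyl goes with this step; a carboxylic acid, an amide or a plain longer alkyl chain on the same oxygen would help to separate the carbonyl from the chain. Also open, as far as these compounds go, is whether the same exchange would give a step of similar size on the core of compound 3.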